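Series notes: aryl-amino triazine coumarin ethers at the fatty acid receptor

This account rests on a few compounds, and the source may have more. Where it says the series, first, only, none or still open, it means among the compounds named here.

Measured so far:
compound 1 `Cc1ccc(Nc2nc(N)nc(COc3ccc4c(C)cc(=O)oc4c3)n2)cc1` — 1790 nM
compound 2 `Cc1cccc(Nc2nc(N)nc(COc3ccc4c(C)cc(=O)oc4c3)n2)c1` — 1780 nM
compound 3 `Cc1cc(=O)oc2cc(OCc3nc(N)nc(Nc4ccc(C(C)C)cc4)n3)ccc12` — 460 nM

In an assay on COS-7 cells for agonist activity at Free fatty acid receptor 1 (Homo sapiens), read by scintillation counting and inositol phosphate accumulation, with a stated time of 90 min (a lower number here means that less compound is needed, a higher number that more compound is needed for the effect), compound 1 gives 1790 nM, the highest number of the three measured. Compound 2 sits within the scatter of it: a 1.0-fold lower number from compound 1 to compound 2 (0.00 log units; within the scatter). Compound 3 stands apart, with a 3.9-fold lower number from compound 1 to compound 3 (0.59 log units; beyond the scatter) and, from the other side, a 3.9-fold lower number from compound 2 to compound 3 (0.59 log units; beyond the scatter).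

The next compound, compound 4 `Cc1cc(=O)oc2cc(OCc3nc(N)nc(Nc4ccc5c(c4)COC5)n3)ccc12`, keeps the shared core of compound 1 and changes only the group on the aniline nitrogen: a group of 9 heavy atoms (8 carbon, 1 oxygen; one five-membered non-aromatic ring with 1 hetero atom, one six-membered aromatic ring of carbon only) in place of a group of 7 heavy atoms (7 carbon; one six-membered aromatic ring of carbon only), on a nitrogen on an aromatic ring.

Which measured steps bear on this? The step from compound 1 to compound 2 shows that moving the methyl around the phenyl ring leaves the number where it is. The step from compound 1 to compound 3 shows that a change of the substituent on that ring can lower the number, though modestly. Within the data shown here, neither step replaces the phenyl by a fused bicyclic group with an oxygen, so the closest precedent is compound 3, and it is only loosely applicable.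

On this basis a modest lowering is expected rather than a large one: a 1.8-fold lower number from compound 1 to compound 4 (0.25 log units; within the scatter). Among the measured compounds shown here, compound 4 is estimated at 1000 nM, with a range from 300 nM to 3500 nM, the range being wide because compound 3 (460 nM) is the only guide to a changed substituent.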

Compound 4, half-maximal effective concentration: 1330 nM
For compound 4 the middle estimate is 1.3-fold (0.12 log units) below the measured one; the range from low to high includes it.
By their numbers in this assay, from the lowest: compound 3; then compounds 4, 2 and 1 (each within the scatter of the next).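

In this assay, the group of 9 heavy atoms with its five-membered non-aromatic ring can stand on this nitrogen in place of either methylphenyl group with no change beyond the scatter (a 1.3-fold lower number from compound 1 to compound 4 (0.13 log units; within the scatter); a 1.3-fold lower number from compound 2 to compound 4 (0.13 log units; within the scatter)). Compound 3 carries the same heavy-atom count at this position as a 4-isopropylphenyl group, yet the two compounds differ beyond the scatter (a 2.9-fold higher number from compound 3 to compound 4 (0.46 log units; beyond the scatter)), so in this pair the count alone does not set the number. Nothing at hand accounts for that gap.

The compounds shown leave open whether the gap to compound 3 follows the ring oxygen or the fused ring itself, a question that the all-carbon counterpart, with a methylene group in place of that oxygen, would separate. Going by these compounds, it is also open how far the number moves on this phenyl ring with a 4-tert-butyl group, a longer chain such as 4-butyl, or a carboxylic acid or amine in place of the alkyl groups, and all four compounds keep the shared core unchanged.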